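Expecting the next cathepsin S nitrile after a side-chain swap

The compounds below may be only part of what the source reports. "The series", "measured", "known", "first", "only" and "open" are said of these compounds alone.

Of the compounds shown here, two have been measured so far in an assay on isolated protein for inhibition of cathepsin S (Homo sapiens), read by fluorescence; on this read-out lower numbers stand for stronger inhibition and higher numbers for weaker inhibition. Compound 1, with the structure `N#Cc1nc(-c2cccc(C(F)(F)F)c2)cc2[nH]cnc12`, gives 1050 nM in this assay. Among the measured compounds shown here, compound 2, with the structure `Cn1cnc2c(C#N)nc(-c3ccc(CCO)c(C(F)(F)F)c3)cc21`, gives 71 nM in this assay; of the two numbers known, this is the lower one, and the gap to compound 1 lies beyond the usual scatter.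

Compound 3, with the structure `Cn1cnc2c(C#N)nc(-c3ccc(OCc4ccncc4)c(C(F)(F)F)c3)cc21`, has not been measured yet. It differs from compound 2 in one place: (pyridin-4-yl)methoxy in place of 2-hydroxyethyl on an aromatic carbon. The group that enters is much larger than the one that leaves, brings an aromatic ring and loses the hydrogen-bond donor.

For the measured compounds named here, no measured pair shows what such a swap does to the number in this assay, so the expectation rests on compound 2 alone. The change is expected to move the number only modestly, with no direction that can be claimed beyond the scatter, as the step of a 1.6-fold lower number from compound 2 to compound 3 (0.20 log units; within the scatter) shows. Compound 3 is therefore estimated to give 45 nM in this assay, within a range from 9 nM to 220 nM.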

Compound 3, half-maximal inhibitory concentration: 10 nM
Compound 3: middle estimate off by 4.5-fold (0.65 log units), on the high side; the measured number falls inside the stated range.
By their numbers in this assay, from the lowest: compound 3; then compound 2; then compound 1.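

In this assay, putting (pyridin-4-yl)methoxy in place of 2-hydroxyethyl gives a 7.1-fold lower number from compound 2 to compound 3 (0.85 log units; beyond the scatter), so the substituent on this aromatic carbon, ortho to a trifluoromethyl group, can shift the number by more than repeat measurements would. The step also shows that, in this pair, a much larger group with an aromatic ring and no hydrogen-bond donor is accepted here, and that the hydrogen-bond donor of 2-hydroxyethyl is not needed to reach a low number. Nothing measured here bears on what lies behind the drop.

The swap changes size, ring content and hydrogen-bond donor count all at once, so this single pair cannot say which of these changes matters, or whether they matter only in combination. The compounds shown leave open how a benzyloxy group, whose ring holds carbon only, would compare, and whether the ring nitrogen's place counts, as a (pyridin-3-yl)methoxy group would test, while a small methoxy group would show how much of the step needs the ring at all.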